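The source may hold more compounds than are shown below. What is called first, only, known or untested is meant among the compounds shown, and "the series" means these compounds.

Series notes, thallium-flux read-out.

Compound 1 `CCC(=O)c1ccc(OCCCCOc2cc(C(=O)O)ccc2OC)c(C)c1O` is the starting point; in an assay on HEK293 cells for positive allosteric modulation of metabotropic glutamate receptor 3 (Rattus norvegicus), read by thallium flux, with a stated time of 2.5 min (on this read-out higher numbers stand for an effect only at larger amounts of compound and lower numbers for an effect already at smaller amounts), compound 1 gives 6360 nM. Compound 2 `COc1ccc(C(=O)O)cc1OCCCCOc1ccc(C(=O)C(C)C)c(O)c1C` carries the change methyl in place of hydrogen on a saturated chain carbon bound to a carbonyl carbon and a saturated chain carbon on the same core, and in this assay compound 2 gives 588 nM. The step of an 11-fold lower number from compound 1 to compound 2 (1.03 log units; beyond the scatter) is the one clear movement recorded so far within the series.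

Compound 3 `CCC(=O)c1ccc(OCCCCOc2ccc(F)c(C(=O)O)c2)c(C)c1O` has been run in this assay, but for compound 3 the entry reads "not determined" (no result reported), so no number stands against compound 3. The difference between the core of compound 3 and the core of compound 1 is not broken down here. Among the measured compounds shown here, compound 4 `Cc1c(OCCCCOc2ccc(F)c(C(=O)O)c2)ccc(C(=O)C(C)C)c1O` is to be measured in this assay and differs from compound 3 by methyl in place of hydrogen on a saturated chain carbon bound to a carbonyl carbon and a saturated chain carbon, which is the same kind of change as the one from compound 1 to compound 2, made at a place described in the same words on a different core.

With no value for compound 3, the expectation for compound 4 cannot be anchored to its own pair; it rests instead on compound 2 and on the size of the step of an 11-fold lower number from compound 1 to compound 2 (1.03 log units; beyond the scatter), which shows that this change can move the read-out a long way on the core of compound 1. From the compounds shown here alone, whether the second core responds alike is unknown, so the range is set wide. In this assay compound 4 is expected to give about 800 nM, with an estimated span from 250 nM to 3000 nM.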

Compound 4, half-maximal effective concentration: > 10000 nM
Compound 4 was reported as a limit (the forecaster's own chance of this, stated with the estimate: 10%); at least 12-fold (1.09 log units) between middle value and limit.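

No new step can be read between compound 3 and compound 4: compound 3 has no reported result, and compound 4 has no single number. In this assay the entry for compound 4 is a limit of the assay: the limit of > 10000 nM in this assay, at which 1 of the 4 values shown sits.

The compounds shown leave open whether ethyl to isopropyl on the core of compound 3 has any effect resembling an 11-fold lower number from compound 1 to compound 2 (1.03 log units; beyond the scatter).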